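A few compounds are considered here, and "the series" means these few. Any claim that something is new, unique, unknown or untested is made for them only; others in the source may bear on it.

Series notes, on the shared core of compound 1 `CC(C)CCSc1nc(C(F)(F)F)ccc1CNC(=O)C(C)c1ccc(NS(C)(=O)=O)c(F)c1` with the sulfur substituent varied. In an assay on CHO-K1 cells for antagonist activity at transient receptor potential cation channel subfamily V member 1 (Homo sapiens), read by FLIPR (on this read-out lower numbers stand for stronger inhibition and higher numbers for weaker inhibition), compound 1 gives 0.7 nM. Compound 2 `CC(C(=O)NCc1ccc(C(F)(F)F)nc1SCCCO)c1ccc(NS(C)(=O)=O)c(F)c1`, carrying the 3-hydroxypropyl on that sulfur, is reported in this assay as "not active" (no number reported), so no single number stands for it. Compound 3 `CC(C(=O)NCc1ccc(C(F)(F)F)nc1[S+]([O-])C1CCCCC1)c1ccc(NS(C)(=O)=O)c(F)c1` is likewise reported in this assay as "not active" (no number reported), a second entry without a single number. Compound 4 `CC1CCC(Sc2nc(C(F)(F)F)ccc2CNC(=O)C(C)c2ccc(NS(C)(=O)=O)c(F)c2)CC1` is not yet measured; it differs from compound 2 in one place: 4-methylcyclohexyl in place of 3-hydroxypropyl on a sulfur. For the measured compounds named here, no measured step of this kind is available. A large step toward stronger inhibition in this assay is expected, well beyond the scatter, given that compound 1 gives 0.7 nM with a hydrocarbon group on the same sulfur. Compound 4 is estimated at 1 nM, within 0.3 nM to 5 nM.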

Compound 4, inhibition constant: 0.5 nM
Estimate against measurement, compound 4: 2.0-fold (0.30 log units) above; low and high end bracket the measured number.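

In this assay, 4-methylcyclohexyl in place of isopentyl on the sulfur gives a 1.4-fold lower number from compound 1 to compound 4 (0.15 log units; within the scatter), so this ring and the open hydrocarbon chain cannot be told apart at this position. Compound 2, with 3-hydroxypropyl, is reported as not active, whereas compound 4 gives 0.5 nM; no step can be read from an entry without a number.

Nothing measured here accounts for this difference. From the compounds shown here alone, whether a plain cyclohexyl on the sulfur, or a 3-aminopropyl, reads like compound 4 or like compound 2 stays open.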